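The compounds below may be only part of what the source reports. "The series", "measured", "known", "first", "only" and "open" are said of these compounds alone.

Measured compounds in the series:

Compound 1 `Cc1ccc2nc(/N=C3\C(=O)N(CN4CCCCC4)c4cccc(Br)c43)sc2c1`: in an ADME assay on 184B5 cells (Homo sapiens) for cytotoxicity, read by sulforhodamine B assay, with a stated time of 48 h (on this read-out lower numbers stand for stronger inhibition of growth and higher numbers for weaker inhibition of growth), compound 1 gives 85200 nM.
Compound 2 `Cc1ccc2nc(/N=C3\C(=O)N(CN(C)C)c4cccc(Cl)c43)sc2c1`: in this assay compound 2 gives 5770 nM.
Compound 3 `Cc1ccc2nc(/N=C3\C(=O)N(CN(C)C)c4cccc(Br)c43)sc2c1`: in this assay compound 3 gives 74800 nM.

Compound 3 stands second highest of the three numbers. Its nearest neighbour is compound 1, with a 1.1-fold lower number from compound 1 to compound 3 (0.06 log units; within the scatter), so these two are not separable. Among the measured compounds shown here, its furthest is compound 2, with a 13-fold higher number from compound 2 to compound 3 (1.11 log units; beyond the scatter), the one large step seen so far in this assay.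

Compound 4 `Cc1ccc2nc(/N=C3\C(=O)N(CN(C)C)c4ccccc43)sc2c1` is not yet measured. It differs from compound 3 at one place: hydrogen in place of bromo on an aromatic carbon.

Of the two measured steps, only the halogen exchange bears on this change, since it sits on the same aromatic carbon; the amine exchange touches a different part of the molecule and was within the scatter anyway. The halogen step was large, which shows that this position can move the number in this assay by more than the scatter. However, it compares two halogens, and nothing measured shows what the unsubstituted position does. The direction is therefore open, with a lower number the more likely outcome given that the bromo compound is the high end of the pair.

Compound 4 is estimated at 25000 nM, with a range of 5000 nM to 120000 nM, which would be a step of a 3.0-fold lower number from compound 3 to compound 4 (0.48 log units; beyond the scatter).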

Compound 4, concentration for 50% growth inhibition: 15600 nM
Compound 4: the middle estimate sits 1.6-fold (0.20 log units) above what was measured; low and high end bracket the measured number.
By their numbers in this assay, from the lowest: compound 2; then compound 4; then compounds 3 and 1 (each within the scatter of the next).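

In this assay, the aromatic carbon that carried the halogen now has an unsubstituted reference, and the two halogens fall on opposite sides of it, with replacement of bromo by hydrogen giving a 4.8-fold lower number from compound 3 to compound 4 (0.68 log units; beyond the scatter) and replacement of chloro by hydrogen giving a 2.7-fold higher number from compound 2 to compound 4 (0.43 log units; beyond the scatter). The large gap between compound 2 and compound 3 therefore splits into two modest steps of opposite direction, so a halogen at this position does not by itself move the number one way: relative to hydrogen, chloro goes with a lower number and bromo with a higher one. No measurement on hand bears on why the two halogens part in this way.

With only hydrogen, chloro and bromo at this position, the compounds leave open where fluoro, iodo, methoxy or nitrile would fall relative to compound 4, and whether the order seen here would extend to any of them. On these data alone, the exchange of dimethylamino for piperidin-1-yl is read only with bromo on the ring, so whether it stays within the scatter with chloro or hydrogen at this position remains open as well.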